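Ring exchange on the ether oxygen of compound 3

The source may hold more compounds than are shown below. What is called first, only, known or untested is meant among the compounds shown, and "the series" means these compounds.

In an assay on HEK293 cells for inhibition of kynurenine 3-monooxygenase (Homo sapiens), read by LC-MS, with a stated time of 20 h (on this read-out lower numbers stand for stronger inhibition and higher numbers for weaker inhibition), compound 3 `O=C(O)CCn1c(=O)oc2cc(OCc3ccccn3)c(Cl)cc21` gives 5010 nM, the highest of the three measured values. Among the measured compounds shown here, compound 1 `C[C@@H](Oc1cc2oc(=O)n(CCC(=O)O)c2cc1Cl)c1ccc(F)cn1` gives 25.1 nM and compound 2 `Cc1ccc([C@@H](C)Oc2cc3oc(=O)n(CCC(=O)O)c3cc2Cl)nc1` gives 6.31 nM; the only measured step, a 4.0-fold lower number from compound 1 to compound 2 (0.60 log units; beyond the scatter), concerns a substituent on the aromatic ring and does not touch the group on the ether oxygen. Compound 4 `C[C@@H](Oc1cc2oc(=O)n(CCC(=O)O)c2cc1Cl)c1ncco1` differs from compound 3 by a group of 7 heavy atoms (5 carbon, 1 nitrogen, 1 oxygen; one five-membered aromatic ring with 2 hetero atoms) in place of a group of 7 heavy atoms (6 carbon, 1 nitrogen; one six-membered aromatic ring with 1 hetero atom), on an oxygen on an aromatic ring. For the measured compounds named here, no measured step covers this exchange; the one indication is that compound 1 and compound 2, which like compound 4 carry a defined stereocentre, lie far below compound 3 in this assay. A substantial downward step is therefore expected, with wide uncertainty about its size. Compound 4 is estimated at 100 nM, range 15 nM to 800 nM, an expected 50-fold lower number from compound 3 to compound 4 (1.70 log units; beyond the scatter).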

Compound 4, half-maximal inhibitory concentration: 7940 nM
For compound 4 the middle estimate is 79-fold (1.90 log units) below the measured one; the whole stated range lies below it.
By their numbers in this assay, from the lowest: compound 2; then compound 1; then compounds 3 and 4 (each within the scatter of the next).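

In this assay, the exchange on the ether oxygen gives a 1.6-fold higher number from compound 3 to compound 4 (0.20 log units; within the scatter), so the oxazole-bearing group with its defined stereocentre reads level with (pyridin-2-yl)methyl. On the saturated chain carbon, 1,3-oxazol-2-yl gives a 1300-fold higher number from compound 2 to compound 4 (3.10 log units; beyond the scatter) and a 320-fold higher number from compound 1 to compound 4 (2.50 log units; beyond the scatter), so the low values of the two substituted pyridines do not carry over to this five-membered ring. No available evidence bears on the cause of these steps.

From the compounds shown here alone, how a 1,3-thiazol-2-yl or phenyl group on that carbon would read remains open. Also open, going by these compounds, is how much of the distance from compound 3 to the two substituted pyridines belongs to the stereocentre and how much to the ring substituents.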